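The source may report more compounds than this note shows. Statements on the series, on what has been measured and on what is new or still open speak of the compounds shown alone.

In an ADME assay on the whole organism with Oryza sativa as the target, tested at 0.1 uM (on this read-out lower numbers stand for a stronger effect and higher numbers for a weaker effect at the one concentration tested), three compounds sharing a core have been examined. Compound 1 `Cc1ccccc1NC(=O)N[C@@H](C)c1ccccc1` gives 100%, compound 2 `C[C@H](NC(=O)Nc1ccccc1F)c1ccccc1` gives 98%, and compound 3 `C[C@@H](NC(=O)Nc1ccc(F)cc1F)c1ccccc1` gives 100%. Compound 1 and compound 3 stand level at the digits shown, and the gap of each to compound 2 lies within the scatter, so no order can be drawn among the three. Among the compounds with values here, the one single-point change among them is methyl in place of fluoro on an aromatic carbon, and it produced a number 2 percentage points higher from compound 2 to compound 1 (within the scatter). How the core of compound 3 differs from that of compound 2 is not broken down here.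

Compound 4 `Cc1ccc(NC(=O)N[C@H](C)c2ccccc2)c(F)c1` has not yet been measured in this assay. It arises from compound 3 by methyl in place of fluoro on an aromatic carbon. Within the data shown here, this is the same kind of change as the one from compound 2 to compound 1, though the surroundings differ: in compound 1 the methyl sits ortho to a large group, whereas in compound 4 it sits meta to a fluoro group and para to a large group. Because the earlier step was a number 2 percentage points higher from compound 2 to compound 1 (within the scatter) and compound 3 already gives 100%, compound 4 is expected to show a number 1 percentage points lower from compound 3 to compound 4 (within the scatter). The estimate for compound 4 is accordingly 99%, expected to fall between 91% and 100%.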

Compound 4, a percentage reported as activity, at one concentration (the size of the read-out at that concentration, not a potency): 98%
Beside the measured number, compound 4's estimate is 1 percentage points above it, and the stated range covers the measured number.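

In this assay, within the data shown here, methyl in place of fluoro on an aromatic carbon gave a number 2 percentage points lower from compound 3 to compound 4 (within the scatter), so on this second core the change again left no step that can be read beyond the scatter. Set beside the earlier case, the two steps do not differ by more than such measurements allow: the same change on two cores in this assay, a number 2 percentage points higher (within the scatter) from compound 2 to compound 1 and a number 2 percentage points lower (within the scatter) from compound 3 to compound 4, 4 percentage points apart, within the scatter of two such steps. This shows that the change had no readable effect on either of these two cores, but it does not show that a real effect of a given size carries from one core to the other, since neither step stands clear of the scatter, and two cores cannot speak for the whole series.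

The compounds shown leave open whether any group on the aromatic ring can shift the read-out beyond the scatter, for instance a methoxy group, a nitrile or a trifluoromethyl group. As far as these compounds go, it also remains open whether an amine or a carboxylic acid in that place would do so.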